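Reversing a sulfonamide for an aryl amide on the shared core

The source may hold more compounds than are shown below. What is called first, only, known or untested is meant among the compounds shown, and "the series" means these compounds.

Of the compounds shown here, three on a shared core have been measured in an assay on isolated protein for inhibition of Rho-associated protein kinase 2 (Homo sapiens), read by scintillation counting, radiometric assay and 33P incorporation, with a stated time of 40 min, in the presence of a further agent that is not named here; on this read-out lower numbers stand for stronger inhibition and higher numbers for weaker inhibition. Compound 1 `Cc1ccc(C(=O)Nc2cccc(NC(=O)COc3ccc4c(=O)ccoc4c3)c2)cc1` gives 22 nM, compound 2 `Cc1cc(C(=O)Nc2cccc(NC(=O)COc3ccc4c(=O)ccoc4c3)c2)no1` gives 5 nM, and compound 3 `Cn1ccc(S(=O)(=O)Nc2cccc(NC(=O)COc3ccc4c(=O)ccoc4c3)c2)n1` gives 1350 nM, the highest number of the three. The steps leading to compound 3 are both large: a 61-fold higher number from compound 1 to compound 3 (1.79 log units; beyond the scatter) and a 270-fold higher number from compound 2 to compound 3 (2.43 log units; beyond the scatter). Compound 4 `NCc1ccc(C(=O)Nc2cccc(NC(=O)COc3ccc4c(=O)ccoc4c3)c2)cc1` is not yet measured. From compound 3 to compound 4 the change is a group of 10 heavy atoms (8 carbon, 1 nitrogen, 1 oxygen; one six-membered aromatic ring of carbon only) in place of a group of 9 heavy atoms (4 carbon, 2 nitrogen, 2 oxygen, 1 sulfur; one five-membered aromatic ring with 2 hetero atoms), on a nitrogen on an aromatic ring. This change largely undoes the step from compound 1 to compound 3, with an aminomethyl on the ring in place of the methyl of compound 1, so the bearing steps are the two above, and a large lower number is expected in this assay, in the direction of compound 1 and compound 2. For compound 4 the estimated value is 20 nM, with a range from 5 nM to 80 nM, which would mean an estimated step of a 68-fold lower number from compound 3 to compound 4 (1.83 log units; beyond the scatter).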

Compound 4, half-maximal inhibitory concentration: 66 nM
Beside the measured number, compound 4's estimate is 3.3-fold (0.52 log units) below it; measured number inside the range.
By their numbers in this assay, from the lowest: compound 2; then compound 1; then compound 4; then compound 3.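

In this assay, the (4-(aminomethyl)phenyl)carbonyl group on this nitrogen gives a 20-fold lower number from compound 3 to compound 4 (1.31 log units; beyond the scatter), so an amide bearing a substituted phenyl ring stays well clear of the sulfonyl compound even without the methyl of compound 1. The amino group is not neutral, however, with amino in place of hydrogen costing a 3.0-fold higher number from compound 1 to compound 4 (0.48 log units; beyond the scatter), a modest step beyond the scatter, and the 5-methyl-1,2-oxazol-3-yl group keeps its lead in a 13-fold higher number from compound 2 to compound 4 (1.12 log units; beyond the scatter). Nothing given here accounts for these shifts.

From the compounds shown here alone, it remains open how much of the high number of compound 3 belongs to the sulfonyl link and how much to its ring, which a 4-methylphenyl group on a sulfonyl would separate. Going by these compounds, it is equally open whether a hydroxymethyl, a carboxylic acid or a longer aminoethyl chain in place of the aminomethyl would raise or lower the number.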